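The compounds below may be only part of what the source reports. "The series", "measured", "known", "first", "only" and "open" are said of these compounds alone.

Among the measured compounds shown here, compound 2 `CN(CC(N)=O)C[C@@H]1CCCc2cc(S(=O)(=O)c3cccc(F)c3)ccc21` gives, in an assay on isolated protein for displacement of a labelled ligand from 5-hydroxytryptamine receptor 6 (Homo sapiens) (on this read-out lower numbers stand for stronger inhibition and higher numbers for weaker inhibition), a reading of 1.26 nM, which is the lower of the two numbers so far. Its partner compound 1 `O=S(=O)(c1cccc(F)c1)c1ccc2c(c1)CCC[C@H]2CN1CCCS1(=O)=O` gives 31.6 nM, and the step of a 25-fold lower number from compound 1 to compound 2 (1.40 log units; beyond the scatter) shows how strongly the tail on the saturated chain carbon bound to a saturated ring carbon can move the number. Compound 3 `CNC(=O)NC[C@@H]1CCCc2cc(S(=O)(=O)c3cccc(F)c3)ccc21` alters that same tail once more: (methylcarbamoyl)amino in place of (carbamoylmethyl)(methyl)amino on a saturated chain carbon bound to a saturated ring carbon. For the measured compounds named here, no measured pair copies this exact exchange, so the one recorded step serves only as a warning that this position is sensitive, not as a guide to direction. Since compound 2 already stands at the low end, the expected step of a 4.0-fold higher number from compound 2 to compound 3 (0.60 log units; beyond the scatter) is a moderate move to a higher number, with a wide band of doubt. For compound 3 the estimate in this assay is 5 nM, expected between 1.3 nM and 25 nM.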

Compound 3, inhibition constant: 0.398 nM
For compound 3 the middle estimate is 13-fold (1.10 log units) above the measured one, and the stated range ends above it.
By their numbers in this assay, from the lowest: compound 3; then compound 2; then compound 1.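

In this assay, the tail on the saturated chain carbon bound to a saturated ring carbon had more room to go lower: putting (methylcarbamoyl)amino in place of (carbamoylmethyl)(methyl)amino gives a 3.2-fold lower number from compound 2 to compound 3 (0.50 log units; beyond the scatter) and sets a new low mark for this set. The wider comparison with the tail carrying the five-membered ring is a 79-fold lower number from compound 1 to compound 3 (1.90 log units; beyond the scatter) and shows that both tails without a ring read lower than the ringed one. No supporting measurement is available to explain why the number falls with this exchange.

The exchange changes the tail's size and its hydrogen-bond donor count together, so the compounds shown do not separate the two. As far as these compounds go, how (ethylcarbamoyl)amino or a simple primary amine would read at this place remains open.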